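Swapping the lactam substituent and watching cell toxicity

The source may report more compounds than this note shows. Statements on the series, on what has been measured and on what is new or still open speak of the compounds shown alone.

Three compounds share a bicyclic core carrying a urea to a trifluorophenyl group and a 2-oxopyrrolidine ring on the aromatic carbon. Compound 1 `CC1CCn2ncc(N3CC(c4ccccc4)CC3=O)c2CN1C(=O)Nc1cc(F)c(F)c(F)c1` carries a phenyl group on that ring. Compound 2 `CC1(C)CC(=O)N(c2cnn3c2CN(C(=O)Nc2cc(F)c(F)c(F)c2)C(C2CC2)C3)C1` carries two methyl groups there, and compound 3 `CC1(C)CN(C(=O)Nc2cc(F)c(F)c(F)c2)Cc2c(N3CC(C#N)CC3=O)cnn21` a nitrile. Going by the values given here, in a toxicity assay on HepG2 2.2.15 cells (Homo sapiens) for cytotoxicity, read by CellTiter-Glo (on this read-out lower numbers stand for higher toxicity in this test and higher numbers for lower toxicity in this test), compound 2 gives 115000 nM, the only plain number among the three. For compound 1 this assay reports only a limit, > 2000 nM, as described by the limit of > 2000 nM in this assay, at which 1 of the 3 values shown sits. For compound 3 this assay likewise reports only a limit, > 200000 nM, as described by the limit of > 200000 nM in this assay, at which 1 of the 3 values shown sits. Among the compounds with values here, compound 2 therefore stands alone as the sole measured number, with the other two values being limits.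

Compound 4 `O=C1CC(c2ncccn2)CN1c1cnn2c1CN(C(=O)Nc1cc(F)c(F)c(F)c1)C(C1CC1)C2` differs from compound 2 in one place: 2-oxo-4-(pyrimidin-2-yl)pyrrolidin-1-yl in place of 4,4-dimethyl-2-oxopyrrolidin-1-yl on an aromatic carbon. Within the data shown here, no pair of measured compounds differs in just one place, so nothing measured shows how such a change moves this assay. With compound 2 giving 115000 nM, the expectation for compound 4 is a step of about a 1.3-fold higher number from compound 2 to compound 4 (0.12 log units; within the scatter), which stays within the scatter. Compound 4 is estimated to give 150000 nM, expected within 40000 nM to 400000 nM.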

Compound 4, half-maximal cytotoxic concentration: > 200000 nM
Compound 4 gave a limit, no number; the forecaster's own chance of this, stated with the estimate: 40%; middle value at least 1.3-fold (0.12 log units) away from the limit.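

Going by these compounds alone, this is the first comparison at this place on the five-membered aromatic ring in which only one group changes: in this assay, 2-oxo-4-(pyrimidin-2-yl)pyrrolidin-1-yl in place of 4,4-dimethyl-2-oxopyrrolidin-1-yl gives an at least 1.7-fold higher number from compound 2 to compound 4 (0.24 log units; that floor lies within the scatter). Compound 4 gives > 200000 nM, which is a limit and not a number, and it shares that limit with one other compound: the limit of > 200000 nM in this assay, at which 2 of the 4 values shown sit. Replacing the two methyl groups with a pyrimidine ring therefore produced no readable drop in the number, which would have meant higher toxicity in this test, but the printed floor of the step is too small to establish a real rise.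

On these data alone, how far the true value of compound 4 lies past its limit remains open, and with it the full size of the step. Also open, as far as these compounds go, is whether an amine or a carboxylic acid in place of the pyrimidin-2-yl group would leave the number out of reach in the same way, or bring it down to a value that can be read.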